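Replacing the 4-bromophenyl group of compound 2

The compounds below may be only part of what the source reports. "The series", "measured", "known", "first", "only" and "open" are said of these compounds alone.

In a functional assay on MDA-MB-231 cells (Homo sapiens) for inhibition, read by MTT assay, with a stated time of 48 h (a lower number here means a stronger inhibitor of growth, a higher number a weaker inhibitor of growth), compound 2 `S=C(Nc1ccc(Br)cc1)Nc1ccc2ncnc(Nc3cccc(Br)c3)c2c1` gives > 30000 nM, and this is a limit of the assay, not a number. Compound 1 `FC(F)(F)c1cc(NC(=S)Nc2ccc3ncnc(Nc4cccc(Br)c4)c3c2)ccc1Cl` gives a true reading of 1100 nM. Compound 3 `S=C(Nc1cc(Cl)cc(Cl)c1)Nc1ccc2ncnc(Nc3cccc(Br)c3)c2c1` carries 3,5-dichlorophenyl in place of 4-bromophenyl on an amide-type nitrogen. Within the data shown here, the one measured step that bears on this change is an at least 27-fold higher number from compound 1 to compound 2 (1.43 log units; beyond the scatter), which also swaps the group on that nitrogen. With 4-bromophenyl gone, a large move toward a lower number is expected, an estimated at least 7.5-fold lower number from compound 2 to compound 3 (0.87 log units; beyond the scatter). For compound 3 the expected value is 4000 nM, with an estimated range of 1000 nM to 25000 nM.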

Compound 3, concentration for 50% growth inhibition: 3000 nM
Beside the measured number, compound 3's estimate is 1.3-fold (0.12 log units) above it; the measured number falls inside the stated range.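

Swapping 4-bromophenyl for 3,5-dichlorophenyl on this amide-type nitrogen gives a real reading: an at least 10-fold lower number from compound 2 to compound 3 (1.00 log units; beyond the scatter). The reading of compound 2 is a limit and not a number: the limit of > 30000 nM in this assay, at which 1 of the 3 values shown sits. A second halogen-bearing ring can therefore restore measurable growth inhibition here, although 3,5-dichlorophenyl still falls short of 4-chloro-3-(trifluoromethyl)phenyl, with a 2.7-fold higher number from compound 1 to compound 3 (0.44 log units; beyond the scatter).

Compound 3 differs from compound 2 in both the halogen and its placing on the ring, and these two changes cannot be told apart here. As far as these compounds go, how a plain phenyl or a 4-methoxyphenyl group would read on this nitrogen stays open.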